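A few compounds are considered here, and "the series" means these few. Any claim that something is new, unique, unknown or untested is made for them only; others in the source may bear on it.

Compound 1, `Nc1cc(N)c2nc(-c3ccccc3)c(NCc3ccc(Cl)c(Cl)c3)nc2c1`, gives 17000 nM.
Compound 2, `CCOC(=O)[C@H](CCC(=O)O)NC(=O)c1ccc(Sc2nc3cc(N)cc(N)c3nc2-c2ccccc2)cc1`, gives 74100 nM.

These two numbers come from a functional assay on RXF 393 cells (Homo sapiens) for inhibition, read by sulforhodamine B assay, with a stated time of 48 h; a higher number here means a weaker inhibitor of growth, a lower number a stronger inhibitor of growth. Of the two measured compounds, compound 1 has the lower number, and the gap to compound 2 is beyond the usual scatter, so compound 1 is the stronger growth inhibitor of the pair on this evidence.

Compound 3, `COc1ccc(CNc2nc3cc(N)cc(N)c3nc2-c2ccccc2)cc1`, has not yet been measured. For the measured compounds named here, it keeps the shared core of compound 1 and changes only one group: 4-methoxyphenyl in place of 3,4-dichlorophenyl on a saturated chain carbon bound to a nitrogen on an aromatic ring. Two chlorine atoms go out and one oxygen comes in, with the count of heavy atoms unchanged.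

Going by the values given here, no measured pair in this set shows what such a change does, so the direction of the step cannot be read off from the numbers at hand. A modest change in either direction, of a size not far beyond the scatter, is the most that can be expected. Compound 3 is therefore estimated to come out somewhat weaker than compound 1, with the estimated step of a 1.8-fold higher number from compound 1 to compound 3 (0.25 log units; within the scatter), giving an expected value of 30000 nM in this assay, within a range of 10000 nM to 100000 nM.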

Compound 3, concentration for total growth inhibition: 18200 nM
For compound 3 the middle estimate is 1.6-fold (0.22 log units) above the measured one; measured number inside the range.
By their numbers in this assay, from the lowest: compounds 1 and 3 (each within the scatter of the next); then compound 2.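

In this assay, putting 4-methoxyphenyl in place of 3,4-dichlorophenyl gives a 1.1-fold higher number from compound 1 to compound 3 (0.03 log units; within the scatter) and so leaves the two compounds indistinguishable in this growth test. For the compounds shown here, this is the first direct look at this position, the group on a saturated chain carbon bound to a nitrogen on an aromatic ring, and it shows that these two quite differently substituted phenyl groups read alike here: one carries two chlorine atoms, the other an oxygen that counts as a hydrogen-bond acceptor, with the same count of heavy atoms. Nothing available explains why the two groups give such similar numbers.

The swap alters both the kind of substituent and the places it occupies on the ring, so the compounds shown cannot separate those two parts, and a plain unsubstituted phenyl or a 4-chlorophenyl would be needed to do so. As far as these compounds go, it also remains open whether the position would tolerate a group of another type, such as a carboxylic acid or an amine on the ring, or a longer chain in place of the single carbon.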